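Removing One Trifluoromethyl From the Urea Aryl Group

The source may hold more compounds than are shown below. What is called first, only, known or untested is meant among the compounds shown, and "the series" means these compounds.

Two measured compounds share a core. Compound 1 `O=C(Nc1cccc(-n2cc(-c3ccncc3)c(-c3cc(O)cc(Cl)c3)n2)c1)Nc1ccc(Cl)c(C(F)(F)F)c1` and compound 2 `COc1cc(Cl)cc(-c2nn(-c3cccc(NC(=O)Nc4cc(C(F)(F)F)cc(C(F)(F)F)c4)c3)cc2-c2ccncc2)c1` differ from each other in more than one place, so their values can only be set side by side. In a functional assay on MDA-MB-231 cells (Homo sapiens) for inhibition, read by sulforhodamine B assay, with a stated time of 48 h, tested at 1 uM (a higher number here means a weaker effect of the compound at the concentration tested, a lower number a stronger effect), compound 1 gives 77%. In this assay compound 2 gives 29%, the lower of the two numbers, and the gap to compound 1 lies well beyond the scatter of the measurement.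

Compound 3 `COc1cc(Cl)cc(-c2nn(-c3cccc(NC(=O)Nc4cccc(C(F)(F)F)c4)c3)cc2-c2ccncc2)c1` is not yet measured. It differs from compound 2 in one place: hydrogen in place of trifluoromethyl on an aromatic carbon. Among the measured compounds shown here, no pair of measured compounds shows this change, so nothing measured tells how large its effect is. Compound 2, with its value of 29%, is the starting point, and with one trifluoromethyl fewer compound 3 is expected to give a higher number, that is a weaker effect at the tested concentration. The expected step is a number 26 percentage points higher from compound 2 to compound 3 (beyond the scatter), in the direction of a weaker effect and beyond the scatter. Compound 3 is estimated at 55%, with a range from 30% to 80%.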

Compound 3, a percentage reported as activity, at one concentration (the size of the read-out at that concentration, not a potency): 71%
The estimate for compound 3 lay 16 percentage points below the measured number; low and high end bracket the measured number.
By their numbers in this assay, from the lowest: compound 2; then compounds 3 and 1 (each within the scatter of the next).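

Hydrogen in place of trifluoromethyl on this aromatic carbon gives a number 42 percentage points higher from compound 2 to compound 3 (beyond the scatter) in this assay, a large step towards a weaker effect at the tested concentration. Among the compounds shown here, the two compounds measured first differed in more than one place, so only this pair isolates the change, and it shows that, with everything else in compound 2 left as it is, the activity at this concentration depends strongly on what sits at this one position, meta to a large group and meta to a trifluoromethyl group. Nothing available on these compounds accounts for the size of this step, so the pair records how large the change is and gives no reason for it.

The compounds shown leave open whether the stronger effect of compound 2 calls for trifluoromethyl in particular or whether a nitrile or a methoxy group on this aromatic carbon would serve as well. They also leave open whether the same step would appear with a hydroxy group in place of the methoxy group of compound 2, and since each number comes from a single concentration, how the change would read as a potency.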